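The source may hold more compounds than are shown below. What is called first, only, known or untested is meant among the compounds shown, and "the series" means these compounds.

Measured so far:
- compound 1, `Fc1ccc2ncc(-c3nn[nH]n3)cc2c1`: < 25 mg/kg in a functional assay on the whole organism (strain Sprague-Dawley) for inhibition, with Rattus norvegicus as the target; on this read-out lower numbers stand for an effect already at smaller amounts and higher numbers for an effect only at larger amounts of compound
- compound 2, `COc1ccc2ncc(-c3nn[nH]n3)cc2c1`: 10 mg/kg in this assay
- compound 3, `COc1ccc2c(=O)c(-c3nn[nH]n3)c[nH]c2c1`: 10 mg/kg in this assay

Compound 1 gives < 25 mg/kg in this assay, and this is a limit of the assay, not a number. Compound 2 gives 10 mg/kg in this assay. Compound 3 gives 10 mg/kg in this assay, so compound 2 and compound 3 stand level within the scatter. Within the data shown here, the only step between two measured compounds, a step that the limit leaves unreadable from compound 1 to compound 2, cannot be sized because the limit of < 25 mg/kg in this assay, at which 1 of the 3 values shown sits, hides one of its ends.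

Compound 4, `c1cc2ncc(-c3nn[nH]n3)cc2cc1OC1CCCCC1`, differs from compound 2 by cyclohexyl in place of methyl on an oxygen on an aromatic ring. Among the measured compounds shown here, no measured step exchanges a small group on this oxygen for a larger one, so nothing sized bears on this change. The expectation is therefore anchored on compound 2 alone, with a step of no change at the digits printed from compound 2 to compound 4 (within the scatter) that is estimated to stay within the scatter. For compound 4 the estimate in this assay is 10 mg/kg, with a range from 3 mg/kg to 30 mg/kg.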

Compound 4, minimum effective dose: 5 mg/kg
Estimate against measurement, compound 4: 2.0-fold (0.30 log units) above; the range from low to high includes it.
By their numbers in this assay, from the lowest: compounds 4, 2 and 3 (each within the scatter of the next).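

In this assay the exchange of methoxy for cyclohexyloxy gives a 2.0-fold lower number from compound 2 to compound 4 (0.30 log units; within the scatter) and so counts as no real difference. Among these compounds, this is the first measured change on the oxygen, and it shows that a single methyl carbon can give way to a cyclohexyl ring of six carbons without the minimum effective dose leaving the scatter. Bulk on this oxygen, at least in the form of this one ring, therefore does not cost the effect seen with compound 2 in the whole animal.

Compound 1 carries a limit and not a number, so the step from it to compound 4 cannot be read because of that limit: the limit of < 25 mg/kg in this assay, at which 1 of the 4 values shown sits.

Going by these compounds, whether an amine, a carboxylic acid or a longer chain on this oxygen would fare the same stays open, as does whether cyclohexyloxy would be accepted on the core of compound 3.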